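From 3-chlorophenyl to 4-fluorophenyl in an antiproliferative series

The source may report more compounds than this note shows. Statements on the series, on what has been measured and on what is new or still open speak of the compounds shown alone.

Of the compounds shown here, three sharing one core have been measured in a functional assay on A549 cells (Homo sapiens) for antiproliferative activity, read by MTT assay, with a stated time of 24 h; a lower number here means a stronger inhibitor, a higher number a weaker inhibitor. Compound 1 (`Cc1ccccc1NNC(=O)c1cccc(NS(=O)(=O)c2cnc(O)nc2O)c1`), which carries 2-methylphenyl, gives 14200 nM. Compound 2 (`Cc1cccc(NNC(=O)c2cccc(NS(=O)(=O)c3cnc(O)nc3O)c2)c1`), which carries 3-methylphenyl, reads > 20000 nM, and this is a limit of the assay, not a number. Compound 3 (`O=C(NNc1cccc(Cl)c1)c1cccc(NS(=O)(=O)c2cnc(O)nc2O)c1`), which carries 3-chlorophenyl, gives 6640 nM, the lower of the two actual numbers.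

The next compound, compound 4 (`O=C(NNc1ccc(F)cc1)c1cccc(NS(=O)(=O)c2cnc(O)nc2O)c1`), has 4-fluorophenyl in place of 3-chlorophenyl on an amine nitrogen. All three measured steps concern this same group. For the measured compounds named here, two of them lead to the best number so far: a 2.1-fold lower number from compound 1 to compound 3 (0.33 log units; beyond the scatter), and an at least 3.0-fold lower number from compound 2 to compound 3 (0.47 log units; beyond the scatter). The third is an at least 1.4-fold higher number from compound 1 to compound 2 (0.14 log units; that floor lies within the scatter).

Going by the values given here, no fluoro compound has been measured, so these steps bear on the change only indirectly. Among the compounds with values here, compound 3 is the only chloro compound, and compound 4 gives up that chloro group, so some of the gain seen in a 2.1-fold lower number from compound 1 to compound 3 (0.33 log units; beyond the scatter) is expected to be lost. The expected change is a 1.8-fold higher number from compound 3 to compound 4 (0.26 log units; within the scatter), a modest move to a higher number. For compound 4 the expected value in this assay is 12000 nM, with an estimated range of 5500 nM to 24000 nM.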

Compound 4, half-maximal inhibitory concentration: > 20000 nM
Compound 4 was reported as a limit; the forecaster's own chance of this, stated with the estimate: 20%; middle value at least 1.6-fold (0.22 log units) away from the limit.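

Compound 4 sits at a limit of the assay, not at a number. Even so, in this assay the change on the amine nitrogen gives an at least 3.0-fold higher number from compound 3 to compound 4 (0.47 log units; beyond the scatter), which shows that a halogen on this phenyl ring does not by itself keep the lower number seen with 3-chlorophenyl, and that compound 3 is set apart from the 4-fluorophenyl compound as well as from the 3-methylphenyl one. Against the other actual number, an at least 1.4-fold higher number from compound 1 to compound 4 (0.14 log units; that floor lies within the scatter) separates little, and the step between the two limits cannot be read, so the order among compounds 1, 2 and 4 stays unsettled: the limit of > 20000 nM in this assay, at which 2 of the 4 values shown sit.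

This change swaps the halogen and its place on the ring in a single step, so the compounds shown cannot tell whether the loss follows the fluoro group or the 4-position; 3-fluorophenyl and 4-chlorophenyl would separate the two. They also leave open whether a 3-bromophenyl group would improve on compound 3, which gives 6640 nM.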